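A few compounds are considered here, and "the series" means these few. Any claim that something is new, unique, unknown or untested is made for them only; others in the source may bear on it.

Within the data shown here, compound 2 `Cc1ccc(Nc2nc(C(F)(F)F)ccc2CNC(=O)C(C)c2ccc(NS(C)(=O)=O)c(F)c2)cc1C` is one of two compounds measured in a functional assay on CHO-K1 cells for antagonist activity at transient receptor potential cation channel subfamily V member 1 (Homo sapiens), read by FLIPR; on this read-out lower numbers stand for stronger inhibition and higher numbers for weaker inhibition. In this assay, among the measured compounds shown here, compound 2 gives 1160 nM, the lower of the two numbers, and the only other measured compound, compound 1 `CC(C(=O)NCc1ccc(C(F)(F)F)nc1Nc1ccccc1)c1ccc(NS(C)(=O)=O)c(F)c1`, gives 1400 nM. For the measured compounds named here, the two sit within the scatter of one another, so neither can be called the more potent; the single measured step, a 1.2-fold lower number from compound 1 to compound 2 (0.08 log units; within the scatter), shows that exchanging one aryl group on the nitrogen for another left the read-out essentially unchanged.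

Compound 3 `Cc1ccc(Cl)cc1Nc1nc(C(F)(F)F)ccc1CNC(=O)C(C)c1ccc(NS(C)(=O)=O)c(F)c1` is the next compound in the series and has not yet been measured. It differs from compound 2 in one place: 5-chloro-2-methylphenyl in place of 3,4-dimethylphenyl on a nitrogen on an aromatic ring. Going by the values given here, the only step that bears on this change is the one from compound 1 to compound 2, which replaced phenyl with 3,4-dimethylphenyl at the same nitrogen and stayed within the scatter. A further swap of one substituted phenyl for another at that position is therefore expected to produce no step beyond the scatter, in either direction. On that basis the estimate for compound 3 in this assay is 1100 nM, with a range from 400 nM to 3000 nM, corresponding to an expected step of a 1.1-fold lower number from compound 2 to compound 3 (0.02 log units; within the scatter).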

Compound 3, half-maximal inhibitory concentration: 140 nM
Compound 3: the middle estimate sits 7.9-fold (0.90 log units) above what was measured; measured number outside the range, below it.
By their numbers in this assay, from the lowest: compound 3; then compounds 2 and 1 (each within the scatter of the next).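

In this assay, among these compounds, the aryl group on a nitrogen on an aromatic ring no longer looks indifferent: 5-chloro-2-methylphenyl in place of 3,4-dimethylphenyl gives an 8.3-fold lower number from compound 2 to compound 3 (0.92 log units; beyond the scatter) and is the first step at this position beyond the scatter. Set against the plain phenyl, the same group gives a 10-fold lower number from compound 1 to compound 3 (1.00 log units; beyond the scatter) while 3,4-dimethylphenyl stayed within the scatter of phenyl, so among these three compounds the read-out depends on which substituted phenyl sits on the nitrogen, and not merely on whether the phenyl carries substituents. Nothing available explains why this exchange moves the read-out.

The compounds shown leave open whether the step belongs to the chlorine, to the methyl or to the two together, and whether a phenyl carrying the chlorine alone or the methyl alone would stand with compound 3 or with compound 2. They also leave open how far the trend extends to other groups on that phenyl, such as a bromine, a methoxy or a nitrile.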